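A few compounds are considered here, and "the series" means these few. Any claim that something is new, unique, unknown or untested is made for them only; others in the source may bear on it.

In a functional assay on PC-3 cells (Homo sapiens) for antiproliferative activity, read by MTT assay, with a stated time of 48 h (on this read-out lower numbers stand for stronger inhibition and higher numbers for weaker inhibition), compound 1 `CCN(CC)CCNC(=O)c1ccc(C(CC)(CC)c2ccc(OCCC(O)(CC)CC)c(C)c2)n1CC` gives 3350 nM. Compound 2 `C#CCCOC(=O)c1ccc(C(CC)(CC)c2ccc(OCCC(O)(CC)CC)c(C)c2)n1CC` gives > 50000 nM, which is a limit of the assay and not a number, and it stands at the limit of > 50000 nM in this assay, at which 1 of the 2 values shown sits. Compound 3 `CCn1c(C(=O)Nc2ccc(OC(F)(F)F)cc2)ccc1C(CC)(CC)c1ccc(OCCC(O)(CC)CC)c(C)c1` differs from compound 2 as follows: (4-(trifluoromethoxy)phenyl)amino in place of (but-3-yn-1-yl)oxy on a carbonyl carbon. In words, (4-(trifluoromethoxy)phenyl)amino takes the place of (but-3-yn-1-yl)oxy on a carbonyl carbon. Among the measured compounds shown here, the one measured step bearing on this is large: an at least 14-fold higher number from compound 1 to compound 2 (1.17 log units; beyond the scatter), with (but-3-yn-1-yl)oxy in place of (2-(diethylamino)ethyl)amino on a carbonyl carbon. Compound 3 again carries an amino group on that carbonyl carbon, and compound 1, with such a group, gives 3350 nM, so a partial return towards lower numbers in this assay is expected. The expected change is an at least 4.1-fold lower number from compound 2 to compound 3 (0.61 log units; beyond the scatter). For compound 3 the estimate is 12000 nM, with an expected range of 3000 nM to 45000 nM.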

Compound 3, half-maximal inhibitory concentration: > 50000 nM
Compound 3: no number, only a limit; the forecaster's own chance of this, stated with the estimate: 25%; at least 4.1-fold (0.61 log units) between middle value and limit.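

In this assay, an amino group on the carbonyl carbon does not by itself give a measurable value: compound 3 carries one, yet its > 50000 nM is a limit of the assay and not a number. With the amide kept, 4-(trifluoromethoxy)phenyl in place of 2-(diethylamino)ethyl on the amide-type nitrogen gives an at least 14-fold higher number from compound 1 to compound 3 (1.17 log units; beyond the scatter), so the group on that nitrogen counts, not the amide alone. The step from compound 2 to compound 3 cannot be read, since both values are limits: the limit of > 50000 nM in this assay, at which 2 of the 3 values shown sit.

Open, going by these compounds, is whether the number of compound 1 depends on the amine at the end of its chain or on the chain itself. A 2-hydroxyethyl or a 3-(diethylamino)propyl on the amide-type nitrogen would bear on this.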